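Swapping 3-bromophenyl for 3,4-dichlorophenyl on the shared core

This account rests on a few compounds, and the source may have more. Where it says the series, first, only, none or still open, it means among the compounds named here.

In an ADME assay on MDBK cells (Bos taurus) for cytotoxicity (on this read-out lower numbers stand for higher toxicity in this test and higher numbers for lower toxicity in this test), compound 1 (`Fc1cccc(Cn2ccc3nc(-c4ccccc4)nc-3c2)c1`) gives > 100000 nM as a limit of the assay and not a number. Compound 2 (`Clc1ccc(Cn2ccc3nc(-c4ccccc4)nc-3c2)cc1`) gives > 100000 nM and this too is a limit. For the measured compounds named here, compound 3 (`Brc1cccc(Cn2ccc3nc(-c4ccccc4)nc-3c2)c1`) gives 85000 nM as the only actual number among the three. Compound 4 (`Clc1ccc(Cn2ccc3nc(-c4ccccc4)nc-3c2)cc1Cl`) carries 3,4-dichlorophenyl in place of 3-bromophenyl on a saturated chain carbon bound to an aromatic nitrogen, a change counted as 3,4-dichlorophenyl in place of 3-bromophenyl on a saturated chain carbon bound to an aromatic nitrogen here. Going by the values given here, two measured steps bear on it, an at least 1.1-fold lower number from compound 1 to compound 3 (0.07 log units; that floor lies within the scatter) and an at least 1.1-fold lower number from compound 2 to compound 3 (0.07 log units; that floor lies within the scatter) and both are floors within the scatter. No step beyond the scatter is therefore expected in this assay and the estimated step is a 1.1-fold lower number from compound 3 to compound 4 (0.03 log units; within the scatter) only. Compound 4 is expected at 80000 nM with a range from 40000 nM to 150000 nM around that estimate.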

Compound 4, half-maximal cytotoxic concentration: 71000 nM
Compound 4: middle estimate off by 1.1-fold (0.05 log units), on the high side; measured number inside the range.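

In this assay, 3,4-dichlorophenyl on a saturated chain carbon bound to an aromatic nitrogen gives a second actual number at this position, and the swap from 3-bromophenyl is a 1.2-fold lower number from compound 3 to compound 4 (0.08 log units; within the scatter). Chloro in place of hydrogen on an aromatic carbon gives an at least 1.4-fold lower number from compound 2 to compound 4 (0.14 log units; that floor lies within the scatter), while 3,4-dichlorophenyl in place of 3-fluorophenyl gives an at least 1.4-fold lower number from compound 1 to compound 4 (0.14 log units; that floor lies within the scatter). Going by these compounds, both floors lie within the scatter, and the true size of these steps stays open because each starts from a limit: the limit of > 100000 nM in this assay, at which 2 of the 4 values shown sit.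

On these data alone, whether an amine, a carboxylic acid or a longer chain at this place would give a step beyond the scatter remains open.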